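The source may hold more compounds than are shown below. What is called first, only, known or untested is meant among the compounds shown, and "the series" means these compounds.

Of the compounds shown here, three built on one shared core have been tested in a functional assay on MDA-MB-231 cells (Homo sapiens) for inhibition, read by sulforhodamine B assay, with a stated time of 48 h, tested at 10 uM; on this read-out lower numbers stand for less inhibition and higher numbers for more inhibition at the one concentration tested (going by the name of the read-out). Compound 1 `c1ccc(-c2cn3ccnc3c(-c3ccc4ncn(C5CCCCC5)c4c3)n2)cc1` carries an unsubstituted phenyl group and gives 41.5%. In this assay compound 2 `c1ccc2c(-c3cn4ccnc4c(-c4ccc5ncn(C6CCCCC6)c5c4)n3)cccc2c1`, which has naphthalen-1-yl in place of phenyl, gives 20.8%, a change described by a number 20.7 percentage points lower from compound 1 to compound 2 (beyond the scatter). Compound 3 `CC(=O)c1ccc(-c2cn3ccnc3c(-c3ccc4ncn(C5CCCCC5)c4c3)n2)cc1`, with acetyl on an aromatic carbon of the phenyl ring, gives 7.65% in this assay; this is the lowest of the three numbers, with compound 2 nearest and compound 1 furthest, and the step of a number 33.9 percentage points lower from compound 1 to compound 3 (beyond the scatter) is the largest of the three seen. Compound 4 `Clc1ccc(-c2cn3ccnc3c(-c3ccc4ncn(C5CCCCC5)c4c3)n2)cc1` has not yet been measured. Its difference from compound 3 is chloro in place of acetyl on an aromatic carbon. For the measured compounds named here, no measured step exchanges acetyl for chloro, so the steps that bear on it are indirect: the step of a number 33.9 percentage points lower from compound 1 to compound 3 (beyond the scatter) shows that adding acetyl on an aromatic carbon lowered inhibition strongly, and taking it away again, even with chloro entering, is expected to give back part of that loss. Compound 4 is therefore expected to give 25% in this assay, between 5% and 48%. The expected step is a number 17.4 percentage points higher from compound 3 to compound 4 (beyond the scatter), a rise of modest size.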

Compound 4, a percentage reported as inhibition, at one concentration (the size of the read-out at that concentration, not a potency): 15.3%
The estimate for compound 4 lay 9.7 percentage points above the measured number; low and high end bracket the measured number.
By their numbers in this assay, from the lowest: compounds 3, 4 and 2 (each within the scatter of the next, the first and the last beyond it); then compound 1.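

In this assay, chloro on this aromatic carbon, para to a large group, also gives a clearly lower number than the unsubstituted phenyl ring (a number 26.2 percentage points lower from compound 1 to compound 4 (beyond the scatter)), so the drop is not confined to acetyl. Exchanging the three heavy atoms of acetyl for a single chlorine atom gives a shift that cannot be told from noise (a number 7.7 percentage points higher from compound 3 to compound 4 (within the scatter)), and the 4-chlorophenyl compound likewise cannot be separated from the naphthalen-1-yl compound (a number 5.5 percentage points lower from compound 2 to compound 4 (within the scatter)). Nothing measured here accounts for the drop seen with either group.

Still open, from the compounds shown here alone, is whether any group at this place keeps the inhibition of the unsubstituted ring, for example an amine, a hydroxyl group or a carboxylic acid. Also open, going by these compounds, is how chloro or acetyl would behave on another carbon of the same ring.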